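The source may hold more compounds than are shown below. What is called first, only, known or untested is meant among the compounds shown, and "the series" means these compounds.

In a functional assay on DU-145 cells (Homo sapiens) for cytotoxicity, read by trypan blue exclusion, with a stated time of 96 h (on this read-out higher numbers stand for weaker inhibition and lower numbers for stronger inhibition), compound 1 `COc1cc(OC)c(/C=C/S(=O)(=O)Nc2ccc(OC)c(F)c2)c(OC)c1` gives 200 nM and compound 2 `COC(=O)C(Nc1cc(NS(=O)(=O)/C=C/c2c(OC)cc(OC)cc2OC)ccc1OC)c1ccc(Br)cc1` gives 7500 nM as the higher of the two numbers, a gap beyond the scatter. Compound 3 `COc1cc(OC)c(/C=C/S(=O)(=O)Nc2ccc(OC)c(NC(C(=O)O)c3ccc(Cl)cc3)c2)c(OC)c1` differs from compound 2 in one place carboxy(4-chlorophenyl)methyl in place of (4-bromophenyl)(methoxycarbonyl)methyl on a nitrogen on an aromatic ring with carboxy(4-chlorophenyl)methyl in place of (4-bromophenyl)(methoxycarbonyl)methyl on a nitrogen on an aromatic ring. Among the compounds with values here, no measured pair shows this change, and only a modest move to a lower number is expected in this assay with a fair chance of none beyond the scatter. The estimated move is a 2.5-fold lower number from compound 2 to compound 3 (0.40 log units; beyond the scatter) in size. For compound 3 the expected value is 3000 nM with 500 nM and 15000 nM as the ends of its range.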

Compound 3, half-maximal inhibitory concentration: 75 nM
Beside the measured number, compound 3's estimate is 40-fold (1.60 log units) above it; the whole stated range lies above it.
By their numbers in this assay, from the lowest: compound 3; then compound 1; then compound 2.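

The change on this nitrogen on an aromatic ring gives, in this assay, a 100-fold lower number from compound 2 to compound 3 (2.00 log units; beyond the scatter), so what hangs on this nitrogen can shift the number strongly. The replacement of fluoro by (carboxy(4-chlorophenyl)methyl)amino gives a 2.7-fold lower number from compound 1 to compound 3 (0.43 log units; beyond the scatter), so a group this large here can give a lower number than fluoro. No measurement here explains the size of either step.

The change swaps the methyl ester for a carboxy group and bromine for chlorine together, so the compounds shown cannot say which swap carries the step. From the compounds shown here alone, how an amide in place of the carboxy group would read also stays open.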